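One Ring Swap, Two Cores, One Cytotoxicity Assay

The source may hold more compounds than are shown below. What is called first, only, known or untested is meant among the compounds shown, and "the series" means these compounds.

Compound 1 `Cc1cc(-n2ccc3ccccc32)cn2c(CSCCc3ccccc3)cnc12` and compound 2 `Cc1cc(-n2ccc3cccnc32)cn2c(CSCCc3ccccc3)cnc12` share one core. Compound 3 `Cc1cc(-n2ccc3ccccc32)c2ncc(CSCCc3ccccc3)n2c1` is made of the same atoms as compound 1 joined differently, and the difference between the two cores is not broken down here. Compound 4 `Cc1cc(-n2ccc3cccnc32)c2ncc(CSCCc3ccccc3)n2c1` has not yet been measured.

In an ADME assay on HEL cells (Homo sapiens) for cytotoxicity, with a stated time of 3 days (a higher number here means that more compound is tolerated, a lower number that less compound is tolerated), compound 1 gives 18 ug/mL. In this assay compound 2 gives 16 ug/mL. The change between them is a group of 9 heavy atoms (7 carbon, 2 nitrogen; one five-membered aromatic ring with 1 hetero atom, one six-membered aromatic ring with 1 hetero atom) in place of a group of 9 heavy atoms (8 carbon, 1 nitrogen; one five-membered aromatic ring with 1 hetero atom, one six-membered aromatic ring of carbon only), on an aromatic carbon, and it made a 1.1-fold lower number from compound 1 to compound 2 (0.05 log units; within the scatter). For compound 3 the assay reports only a limit, > 100 ug/mL in this assay. The change from compound 3 to compound 4 is a group of 9 heavy atoms (7 carbon, 2 nitrogen; one five-membered aromatic ring with 1 hetero atom, one six-membered aromatic ring with 1 hetero atom) in place of a group of 9 heavy atoms (8 carbon, 1 nitrogen; one five-membered aromatic ring with 1 hetero atom, one six-membered aromatic ring of carbon only), on an aromatic carbon. Within the data shown here, this is the same kind of change as the one from compound 1 to compound 2, though the surroundings differ: in compound 1 the group sits para to a fused ring, whereas in compound 3 it sits ortho to a fused ring and meta to a fused ring.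

The step from compound 3 to compound 4 is expected to be a number no higher from compound 3 to compound 4 (the limit leaves the size open), resting on the earlier step of a 1.1-fold lower number from compound 1 to compound 2 (0.05 log units; within the scatter), which stayed within the scatter. Because compound 3 sits at the limit of > 100 ug/mL in this assay, at which 1 of the 3 values shown sits, the starting point of this step is itself only a limit. Compound 4 is therefore estimated at 100 ug/mL, with a range from 40 ug/mL to 250 ug/mL, and a sizeable chance that the assay again reports only a limit.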

Compound 4, half-maximal cytotoxic concentration: > 100 ug/mL
Compound 4: only a limit was reported; the forecaster's own chance of this, stated with the estimate: 70%; the middle value lies on the limit itself.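

No new step can be read between compound 3 and compound 4, because this assay gives only a limit for both, so the size of any difference between them stays hidden: the limit of > 100 ug/mL in this assay, at which 2 of the 4 values shown sit.

Still open, as far as these compounds go, is how far past that limit compound 3 and compound 4 really lie, and so whether swapping the 1H-indol-1-yl group changes tolerance at all on their core.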